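The source may hold more compounds than are shown below. What is called first, only, known or untested is meant among the compounds shown, and "the series" means these compounds.

Compound 1, `COc1cc([C@H]2Oc3cc(OC)c(OC)c(OC)c3C(=O)[C@@H]2O)ccc1O`, gives 5500 nM in a functional assay on liver (Rattus norvegicus) for inhibition, with a stated time of 1 h; a lower number here means that less compound is needed, a higher number that more compound is needed for the effect. Within the data shown here, its relative compound 3, `COc1cc2c(c(OC)c1OC)C(=O)[C@H](O)[C@@H](c1ccc(O)c(O)c1)O2`, carries the change hydrogen in place of methyl on an oxygen on an aromatic ring and in this assay compound 3 gives 10400 nM; the step of a 1.9-fold higher number from compound 1 to compound 3 (0.28 log units; within the scatter) is the only measured example of this change. Compound 2, `COc1cc([C@@H]2Oc3cc(OC)c(OC)c(OC)c3C(=O)[C@@H]2O)cc(OC)c1OC`, has a core that differs from that of compound 1 in a way not broken down here; in this assay compound 2 gives 19600 nM, the highest of the three numbers, with compound 3 within the scatter of it and compound 1 beyond it. Compound 4, `COc1cc([C@@H]2Oc3cc(OC)c(OC)c(OC)c3C(=O)[C@@H]2O)cc(OC)c1O`, is not yet measured and differs from compound 2 by hydrogen in place of methyl on an oxygen on an aromatic ring, the same change as that from compound 1 to compound 3, at the same kind of place. Among the measured compounds shown here, because the only earlier example, a 1.9-fold higher number from compound 1 to compound 3 (0.28 log units; within the scatter), stayed within the scatter, a step of about a 1.5-fold higher number from compound 2 to compound 4 (0.18 log units; within the scatter) is expected here as well, resting on that single precedent. On that basis compound 4 is estimated at 30000 nM in this assay, within a range of 12000 nM to 75000 nM.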

Compound 4, half-maximal effective concentration: 10400 nM
Estimate against measurement, compound 4: 2.9-fold (0.46 log units) above; measured number outside the range, below it.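

In this assay the change from methoxy to hydroxy gives a 1.9-fold lower number from compound 2 to compound 4 (0.28 log units; within the scatter), and set beside the earlier example, the same change does not carry a fixed step from one core to the other: the same change on two cores in this assay, a 1.9-fold higher number (0.28 log units; within the scatter) from compound 1 to compound 3 and a 1.9-fold lower number (0.28 log units; within the scatter) from compound 2 to compound 4, 3.6-fold (0.55 log units) apart, beyond the scatter of two such steps.

What holds for this change on the core of compound 1 therefore could not be transferred unchanged to the core of compound 2, even though the two examples involve the same kind of place, an oxygen on an aromatic ring. This does not show that the change acts in a set direction on either core, since each step taken alone lies within the scatter, and two examples give no rule for predicting its outcome on a further core, nor do they give a reason for the gap.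

The compounds shown leave open how a third core would respond to the same change. They also leave open what an amine, a carboxylic acid or a longer chain such as ethoxy would do at this place in place of methoxy or hydroxy.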